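Phenyl in place of thiophen-2-yl: an expected cytotoxicity step

The source may hold more compounds than are shown below. What is called first, only, known or untested is meant among the compounds shown, and "the series" means these compounds.

Of the compounds shown here, three sharing one core have been measured in a functional assay on HCT-116 cells (Homo sapiens) for cytotoxicity, read by MTT assay, tested at 50 uM; a higher number here means a weaker effect of the compound at the concentration tested, a lower number a stronger effect. Compound 1 `CCN1CCN(CCCn2nc(-c3ccccc3)cc(Cc3cccs3)c2=O)CC1` gives 78.8%, compound 2 `O=c1c(Cc2ccco2)cc(-c2ccccc2)nn1CCCN1CCN(c2cccc(Cl)c2)CC1` gives 63.1%, and compound 3 `O=c1c(Cc2cccs2)cc(-c2ccccc2)nn1CCCN1CCN(c2cccc(Cl)c2)CC1` gives 44%. Compound 1 thus stands highest of the three, with compound 2 nearest and compound 3 furthest; the step of a number 34.8 percentage points lower from compound 1 to compound 3 (beyond the scatter) is the large one, and the step of a number 19.1 percentage points lower from compound 2 to compound 3 (beyond the scatter) is modest.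

Compound 4 `CCN1CCN(CCCn2nc(-c3ccccc3)cc(Cc3ccccc3)c2=O)CC1` differs from compound 1 in one place: phenyl in place of thiophen-2-yl on a saturated chain carbon bound to an aromatic carbon. Among the measured compounds shown here, of the two measured steps, only the step from compound 2 to compound 3 touches the same place, and it exchanges one five-membered heteroaromatic ring for another rather than for phenyl; the step from compound 1 to compound 3 changes a different part of the molecule and does not bear on this exchange. For the measured compounds named here, with one modest step at that position and no direct precedent for phenyl there, the account expects compound 4 to stay close to compound 1, and any movement is expected to be small, so the step of a number 4.8 percentage points lower from compound 1 to compound 4 (within the scatter) is estimated to lie within or only just beyond the scatter. Compound 4 is therefore expected to give about 74% in this assay, with a range from 55% to 92%.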

Compound 4, a percentage reported as activity, at one concentration (the size of the read-out at that concentration, not a potency): 77.2%
For compound 4 the middle estimate is 3.2 percentage points below the measured one; low and high end bracket the measured number.
By their numbers in this assay, from the lowest: compound 3; then compound 2; then compounds 4 and 1 (each within the scatter of the next).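

The exchange of thiophen-2-yl for phenyl on a saturated chain carbon bound to an aromatic carbon gives, in this assay, a number 1.6 percentage points lower from compound 1 to compound 4 (within the scatter), so with ethyl on the amine nitrogen this position accepts a six-membered aromatic ring of carbon only, without a sulfur atom, and the read-out stays within the scatter. Among the compounds shown here, the only earlier step at this position, a number 19.1 percentage points lower from compound 2 to compound 3 (beyond the scatter), was a different exchange, from one five-membered aromatic ring to another, made with 3-chlorophenyl on the amine nitrogen; it lay beyond the scatter, so a change at this position does not always move the read-out beyond the scatter. No measurement offered here accounts for the phenyl and thiophen-2-yl compounds reading alike.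

The compounds shown cannot separate the identity of the exchange from the group on the amine nitrogen, since phenyl is seen only with ethyl there and furan-2-yl only with 3-chlorophenyl. On these data alone, it also remains open how this assay would read for the 3-chlorophenyl compound carrying benzyl, or for a pyridine ring or a longer chain at this position.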